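Swapping the Pyridine Ring of Compound 3 for a Pyrazine

A few compounds are considered here, and "the series" means these few. Any claim that something is new, unique, unknown or untested is made for them only; others in the source may bear on it.

Among the compounds with values here, in a functional assay on CHO-K1 cells for antagonist activity at adenosine receptor A1 (Homo sapiens), read by a beta-galactosidase reporter and cAMP accumulation, with stated times of 15 min and 6 h (a lower number here means a stronger inhibitor, a higher number a weaker inhibitor), compound 3 `Nc1nc(-c2cccnc2)nc2sc(Cc3ccccc3)cc12` gives 1420 nM, the second highest of the three numbers measured so far. Compound 1 `CCc1ccc(-c2nc(N)c3cc(Cc4ccccc4)sc3n2)o1` gives 223 nM, and compound 2 `N#Cc1ccc(-c2nc(N)c3cc(Cc4ccccc4)sc3n2)o1` gives 3160 nM. The steps of a 6.4-fold higher number from compound 1 to compound 3 (0.80 log units; beyond the scatter) and a 2.2-fold lower number from compound 2 to compound 3 (0.35 log units; beyond the scatter) both exchange the ring attached to the shared core, as does the step of a 14-fold higher number from compound 1 to compound 2 (1.15 log units; beyond the scatter); each moved the number beyond the scatter. Compound 4 `Nc1nc(-c2cnccn2)nc2sc(Cc3ccccc3)cc12` differs from compound 3 by pyrazin-2-yl in place of pyridin-3-yl on an aromatic carbon. Within the data shown here, no measured step exchanges one six-membered ring for another, so the expectation rests on the general sensitivity of this position and points to a modest rise in the number: a 1.5-fold higher number from compound 3 to compound 4 (0.19 log units; within the scatter). Compound 4 is estimated at 2200 nM, within a range from 700 nM to 7000 nM.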

Compound 4, inhibition constant: 91 nM
For compound 4 the middle estimate is 24-fold (1.38 log units) above the measured one, outside the stated range (below it).
By their numbers in this assay, from the lowest: compound 4; then compound 1; then compound 3; then compound 2.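

With six-membered rings on this carbon, trading pyridin-3-yl for pyrazin-2-yl, which carries 2 ring hetero atoms instead of 1, gives a 16-fold lower number from compound 3 to compound 4 (1.19 log units; beyond the scatter), so a change within the ring itself can matter greatly here. The earlier steps had not shown this, as each exchanged the ring for a different kind. Within the data shown here, a furan is also not needed for the lowest number so far, given a 35-fold lower number from compound 2 to compound 4 (1.54 log units; beyond the scatter) and a 2.5-fold lower number from compound 1 to compound 4 (0.39 log units; beyond the scatter).

Nothing available explains why the pyrazine differs so sharply from the pyridine. On these data alone, whether a pyrimidine ring or a plain phenyl ring would track compound 3 or compound 4 remains open.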